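The compounds below may be only part of what the source reports. "The series", "measured", "known", "first", "only" and "open" are said of these compounds alone.

Compound 1 `COc1cccc(-c2c(C)nn(-c3nc(-c4ccc(Cl)c(Cl)c4)c(SC(C)C)s3)c2C(=O)O)c1`: 14000 nM
Compound 2 `Cc1cc(-c2c(C)nn(-c3nc(-c4ccc(Cl)c(Cl)c4)c(SC(C)C)s3)c2C(=O)O)cc(C)n1`: 580 nM
Compound 3 `Cc1nn(-c2nc(-c3ccc(Cl)c(Cl)c3)c(SC(C)C)s2)c(C(=O)O)c1-c1cccnc1`: 12000 nM

The three measured compounds share one core and differ only in the aryl group attached to an aromatic carbon of the five-membered ring. In a functional assay on BJAB cells (Homo sapiens) for antiproliferative activity, with a stated time of 4 days (a higher number here means that more compound is needed for the effect, a lower number that less compound is needed), compound 2 gives 580 nM, compound 1 gives 14000 nM and compound 3 gives 12000 nM. Compound 3 thus has the second highest number of the three: the step of a 1.2-fold lower number from compound 1 to compound 3 (0.07 log units; within the scatter) is within the scatter, whereas a 21-fold higher number from compound 2 to compound 3 (1.32 log units; beyond the scatter) is a large rise.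

Compound 4 `Cc1nn(-c2nc(-c3ccc(Cl)c(Cl)c3)c(SC(C)C)s2)c(C(=O)O)c1-c1cccc(F)c1` carries 3-fluorophenyl in place of pyridin-3-yl on an aromatic carbon. The measured step that bears most closely on this is a 1.2-fold lower number from compound 1 to compound 3 (0.07 log units; within the scatter), where 3-methoxyphenyl gave way to pyridin-3-yl with no change beyond the scatter; compound 4 goes back to a ring of carbon only with a different substituent. The large steps of a 24-fold lower number from compound 1 to compound 2 (1.38 log units; beyond the scatter) and a 21-fold higher number from compound 2 to compound 3 (1.32 log units; beyond the scatter) both involve 2,6-dimethylpyridin-4-yl, which plays no part here. Compound 4 is therefore expected to show a step of a 1.1-fold higher number from compound 3 to compound 4 (0.03 log units; within the scatter), within the scatter. Compound 4 is estimated at 13000 nM, with a range from 5000 nM to 35000 nM.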

Compound 4, half-maximal effective concentration: 900 nM
Estimate against measurement, compound 4: 14-fold (1.16 log units) above, and the stated range ends above it.
By their numbers in this assay, from the lowest: compounds 2 and 4 (each within the scatter of the next); then compounds 3 and 1 (each within the scatter of the next).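

In this assay, for the compounds shown here, the earlier compounds tied a low number to 2,6-dimethylpyridin-4-yl alone, but a 13-fold lower number from compound 3 to compound 4 (1.12 log units; beyond the scatter) and a 16-fold lower number from compound 1 to compound 4 (1.19 log units; beyond the scatter) show that 3-fluorophenyl at this position also gives a low number, while a 1.6-fold higher number from compound 2 to compound 4 (0.19 log units; within the scatter) stays within the scatter. Ring type does not sort these four compounds: carbon-only rings appear in both the low pair (compound 4) and the high pair (compound 1), as do pyridinyl groups (compound 2 and compound 3), and fluoro in place of methoxy on the phenyl ring is enough to separate compound 4 from compound 1. Nothing shown here gives a measured reason for these steps.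

Going by these compounds, it remains open whether the low number is particular to fluoro or would also hold for chloro, methyl or nitrile on the phenyl ring. The compounds also leave open how an unsubstituted phenyl or an amine on that ring would compare.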